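A few compounds are considered here, and "the series" means these few. Any claim that something is new, unique, unknown or untested is made for them only; others in the source may bear on it.

In an in vitro ADME assay on microsomes from liver (Homo sapiens) for metabolic stability, tested at 1 uM (a lower number here means that the compound disappears faster, a higher number that the compound lasts longer), compound 2 `CC(C)C(=O)N1C[C@@H]2C[C@H]1CN2C(=O)[C@@]1(C(C)C)CC[C@@H](NC2CCOCC2)C1` gives > 2 h, which is a limit and not a number. Compound 1 `CC(C)[C@]1(C(=O)N2C[C@@H]3C[C@H]2CN3C(=O)OC(C)(C)C)CC[C@@H](NC2CCOCC2)C1` gives > 2 h, also a limit. Compound 3 `CC(C)[C@]1(C(=O)N2C[C@@H]3C[C@H]2CN3C(=O)C2CCCC2)CC[C@@H](NC2CCOCC2)C1` gives > 2 h, again a limit. Within the data shown here, the series so far therefore rests on (the limit of > 2 h in this assay, at which 3 of the 3 values shown sit). Compound 4 `CC(OC(=O)N1C[C@@H]2C[C@H]1CN2C(=O)[C@@]1(C(C)C)CC[C@@H](NC2CCOCC2)C1)C(F)(F)F` differs from compound 2 by 1-(trifluoromethyl)ethoxy in place of isopropyl on a carbonyl carbon, with 1-(trifluoromethyl)ethoxy in place of isopropyl on a carbonyl carbon. Among the measured compounds shown here, the steps that bear on this are a step that the two limits leave unreadable from compound 1 to compound 2, a step that the two limits leave unreadable from compound 1 to compound 3 and a step that the two limits leave unreadable from compound 2 to compound 3, and none of them has a size. For the measured compounds named here, with no measured step to draw on, no change beyond the scatter is expected, and no direction is favoured. The expected step is a step that the limit leaves unreadable from compound 2 to compound 4. For compound 4 the estimated half-life is 2.5 h, with an expected range of 1.2 h to 5 h.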

Compound 4, half-life: 1.3 h
The estimate for compound 4 lay 1.9-fold (0.28 log units) above the measured number; measured number inside the range.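

In this assay, among these compounds, 1-(trifluoromethyl)ethoxy on the carbonyl carbon gives the first reading that is not a limit, with an at least 1.5-fold lower number from compound 2 to compound 4 (0.18 log units; that floor lies within the scatter), an at least 1.5-fold lower number from compound 3 to compound 4 (0.18 log units; that floor lies within the scatter) and an at least 1.5-fold lower number from compound 1 to compound 4 (0.18 log units; that floor lies within the scatter). These are floors only, so the true size of each step stays unfixed, and the steps among compound 1, compound 2 and compound 3 cannot be read. The other values remain limits: the limit of > 2 h in this assay, at which 3 of the 4 values shown sit.

Still open, going by these compounds, is how far compound 1, compound 2 and compound 3 lie beyond their limits. Also open, on these data alone, is how a dimethylamino group or a longer alkyl chain on this carbonyl carbon would read.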